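Swapping a benzyl for a pyridazinyl group on the ether

This account rests on a few compounds, and the source may have more. Where it says the series, first, only, none or still open, it means among the compounds named here.

Compound 3 `O=C(O)CCn1c(=O)oc2cc(OCc3ccccc3)c(Cl)cc21` gives 25.1 nM in an assay for inhibition of kynurenine 3-monooxygenase (Homo sapiens), read by mass spectrometry, with a stated time of 1 h; a lower number here means a stronger inhibitor, a higher number a weaker inhibitor. That is the second highest of the three numbers: compound 1 `COCCOc1cc2oc(=O)n(CCC(=O)O)c2cc1Cl` gives 31.6 nM, and compound 2 `C[C@@H](Oc1cc2oc(=O)n(CCC(=O)O)c2cc1Cl)c1ccc(F)cn1` gives 2.51 nM. Going by the values given here, the only single-point step on record, a 1.3-fold lower number from compound 1 to compound 3 (0.10 log units; within the scatter), shows that exchanging one group for another on the ring oxygen barely moved the number. Compound 4 `C[C@@H](Oc1cc2oc(=O)n(CCC(=O)O)c2cc1Cl)c1cccnn1` carries a group of 8 heavy atoms (6 carbon, 2 nitrogen; one six-membered aromatic ring with 2 hetero atoms) in place of a group of 7 heavy atoms (7 carbon; one six-membered aromatic ring of carbon only), on an oxygen on an aromatic ring. Among the compounds with values here, because compound 2 gives 2.51 nM with a related ring-bearing group on that oxygen, a stronger inhibitor than compound 3 is expected, though no measured step covers this exact change. The expected step is a 4.2-fold lower number from compound 3 to compound 4 (0.62 log units; beyond the scatter), so compound 4 is estimated at 6 nM, within a range from 1.5 nM to 25 nM.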

Compound 4, half-maximal inhibitory concentration: 1.26 nM
For compound 4 the middle estimate is 4.8-fold (0.68 log units) above the measured one; the measured number lies below the stated range.
By their numbers in this assay, from the lowest: compounds 4 and 2 (each within the scatter of the next); then compounds 3 and 1 (each within the scatter of the next).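

In this assay the group on the ring oxygen turns out to matter a great deal: a 20-fold lower number from compound 3 to compound 4 (1.30 log units; beyond the scatter) and a 25-fold lower number from compound 1 to compound 4 (1.40 log units; beyond the scatter) are both large, unlike the earlier exchange there. Between the two ring-bearing branched groups, a 2.0-fold lower number from compound 2 to compound 4 (0.30 log units; within the scatter) stays within the scatter, so 5-fluoropyridin-2-yl and pyridazin-3-yl cannot be told apart here. No measurement at hand accounts for the large steps.

From the compounds shown here alone, compound 4 differs from compound 3 in both its ring and its branched carbon with a defined stereocentre, so the share of each remains open. A phenyl ring on that same branched carbon would separate the two.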